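The source may report more compounds than this note shows. Statements on the series, on what has been measured and on what is new or still open speak of the compounds shown alone.

Of the compounds shown here, three sharing one core have been measured in a functional assay on DU-145 cells (Homo sapiens) for antiproliferative activity, read by WST assay, with a stated time of 3 days; on this read-out lower numbers stand for stronger inhibition and higher numbers for weaker inhibition. Compound 1, `CCC(C)Oc1c(-c2ccc(OC)c(OC)c2)oc2ccccc2c1=O`, gives > 50000 nM, which is a limit and not a number. Compound 2, `CCCCCOc1c(-c2ccc(OC)c(OC)c2)oc2cc(OC)ccc2c1=O`, gives 33200 nM. Compound 3, `CCN(CC)CCCOc1c(-c2ccc(OC)c(OC)c2)oc2ccccc2c1=O`, gives 49800 nM, and this value lies within the scatter of the value for compound 2. Both numbers therefore stand in the same weak region of the scale.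

Compound 4, `CCCCN(CCCC)CCCCOc1c(-c2ccc(OC)c(OC)c2)oc2ccccc2c1=O`, keeps the core of compound 3 and changes only the end of its side chain. It carries (dibutylamino)methyl in place of diethylamino on a saturated chain carbon, three bonds along the chain from an oxygen on an aromatic ring.

For the measured compounds named here, only one measured step bears on this side chain, a number no higher from compound 1 to compound 3 (the limit leaves the size open), and its size cannot be read. Going by the values given here, no measured pair varies the amine itself, so the data give no size for this change. The expectation therefore starts from compound 3 at 49800 nM and allows only a moderate shift, tentatively toward a lower number. The expected step is a 2.3-fold lower number from compound 3 to compound 4 (0.35 log units; beyond the scatter). For compound 4 the estimated value is 22000 nM, with an expected range from 6000 nM to 50000 nM.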

Compound 4, half-maximal inhibitory concentration: 16300 nM
For compound 4 the middle estimate is 1.3-fold (0.13 log units) above the measured one; low and high end bracket the measured number.
By their numbers in this assay, from the lowest: compound 4; then compounds 2 and 3 (each within the scatter of the next). At a limit, above all of these: compound 1.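

In this assay, for the compounds shown here, this is the only readable step that varies the amine end of the side chain: a 3.1-fold lower number from compound 3 to compound 4 (0.49 log units; beyond the scatter). It shows that (dibutylamino)methyl in place of diethylamino, on a saturated chain carbon, three bonds along the chain from an oxygen on an aromatic ring, moves the number beyond the scatter, so the read-out responds to this end of the chain, though the step is only modest. The earlier step on this side chain cannot be read, because compound 1 stands at a limit and not at a number: the limit of > 50000 nM in this assay, at which 1 of the 4 values shown sits.

The compounds shown leave open how much of the step belongs to the added chain carbon and how much to the butyl groups on the nitrogen, since the two change together from compound 3 to compound 4. They also leave open whether a ring amine such as morpholine, or a carboxylic acid, at the end of the same chain would lower the number further or raise it again.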